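Aryl amine variants on the shared core: growth inhibition

The source may report more compounds than this note shows. Statements on the series, on what has been measured and on what is new or still open speak of the compounds shown alone.

Measured compounds:
compound 1 `Cc1cc(Cl)ccc1Nc1ncc(C(F)(F)F)c(N2Cc3cccc(N(C)S(C)(=O)=O)c3C2)n1` — > 30000 nM
compound 2 `COc1ccc(C(F)(F)F)cc1Nc1ncc(C(F)(F)F)c(N2Cc3cccc(N(C)S(C)(=O)=O)c3C2)n1` — > 30000 nM

In a functional assay on OVCAR-3 cells (Homo sapiens) for antiproliferative activity, read by spectrophotometry, with a stated time of 2 days (a lower number here means a stronger inhibitor of growth, a higher number a weaker inhibitor of growth), compound 1 gives only a limit of the assay, > 30000 nM. In this assay compound 2 likewise gives only a limit, > 30000 nM. For the measured compounds named here, the only measured step, a step that the two limits leave unreadable from compound 1 to compound 2, is therefore unreadable: both ends sit at the limit of > 30000 nM in this assay, at which 2 of the 2 values shown sit, and no direction or size can be taken from it.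

Compound 3 `Cc1ccc(Nc2ncc(C(F)(F)F)c(N3Cc4cccc(N(C)S(C)(=O)=O)c4C3)n2)c(Cl)c1` is to be measured in this assay. It differs from compound 2 as follows: 2-chloro-4-methylphenyl in place of 2-methoxy-5-(trifluoromethyl)phenyl on a nitrogen on an aromatic ring. Going by the values given here, the incoming group carries the same chlorine and methyl as the group in compound 1, only in another arrangement, and no measured step bears on such a rearrangement. Both measured compounds stopped at the limit, so compound 3 is expected to stay at or near that limit as well, an estimated step of a number no higher from compound 2 to compound 3 (the limit leaves the size open).

For compound 3 the expected value is 30000 nM, within 8000 nM to 100000 nM.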

Compound 3, concentration for 50% growth inhibition: > 30000 nM
Compound 3 ended at the assay's limit; the forecaster's own chance of this, stated with the estimate: 75%; the middle value lies on the limit itself.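

In this assay compound 3 also ends at a limit, so no step among compound 1, compound 2 and compound 3 can be read: the limit of > 30000 nM in this assay, at which 3 of the 3 values shown sit.

The compounds shown leave open how these aryl amine groups rank against one another and whether any gives a measurable concentration for growth inhibition.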